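The source may hold more compounds than are shown below. What is called first, only, known or untested is meant among the compounds shown, and "the series" means these compounds.

Compounds with measured values:
Compound 1, `O=c1c2cc(Br)ccc2nc(CSc2nnc(-c3ccncc3)o2)n1/N=C/c1ccc(O)cc1`: in a functional assay on the whole organism (strain Charles-Foster albino) for inhibition, with Rattus norvegicus as the target, read by paw edema, at a dose of 50 mg/kg by the oral route (on this read-out higher numbers stand for more inhibition at the one dose given (going by the name of the read-out) and lower numbers for less inhibition), compound 1 gives 22.3%.
Compound 2, `O=c1c2cc(Br)ccc2nc(CSc2nnc(-c3ccncc3)o2)n1/N=C/c1ccc(Cl)cc1`: compound 2 gives 26.4%.
Compound 3, `O=C1CSC(c2ccc(O)cc2)N1n1c(CSc2nnc(-c3ccncc3)o2)nc2ccccc2c1=O`: compound 3 gives 31.7%.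

Compound 1 and compound 2 share one core and differ in a single place, (chloro in place of hydroxy on an aromatic carbon). This change made a number 4.1 percentage points higher from compound 1 to compound 2 (within the scatter), so the two values cannot be told apart. Compound 3 rests on a different core; the difference between the two cores is not broken down here, and its value sits close to both of the others.

Compound 4, `O=C1CSC(c2ccc(Cl)cc2)N1n1c(CSc2nnc(-c3ccncc3)o2)nc2ccccc2c1=O`, has not yet been measured. It stands to compound 3 as compound 2 stands to compound 1, the same change at the same kind of place: chloro in place of hydroxy on an aromatic carbon.

The expectation for the step is a number 3.3 percentage points higher from compound 3 to compound 4 (within the scatter). Going by the values given here, it is put this way because a number 4.1 percentage points higher from compound 1 to compound 2 (within the scatter) is the only direct guide to this change. Compound 4 is therefore estimated at 35%, with a likely range from 22% to 48%.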

Compound 4, a percentage reported as inhibition, in the whole organism at one dose (the size of the read-out at that dose, not a potency): 34.1%
Estimate against measurement, compound 4: 0.9 percentage points above, within the range that was stated.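

In this assay, replacing 4-hydroxyphenyl with 4-chlorophenyl gives a number 2.4 percentage points higher from compound 3 to compound 4 (within the scatter). The same swap on the other core points the same way and by a similar amount, so on these two cores the change carries over without any visible difference in its size: the same change on two cores in this assay, a number 4.1 percentage points higher (within the scatter) from compound 1 to compound 2 and a number 2.4 percentage points higher (within the scatter) from compound 3 to compound 4, 1.7 percentage points apart, within the scatter of two such steps. This does not show that the swap truly raises inhibition, since neither step can be told from the ordinary spread of repeated measurements, and two cores with small steps say little about how the change would behave on a third core.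

The compounds shown leave open whether a different group on the same aromatic carbon, such as an amine, a methoxy group or a carboxylic acid, would shift the value beyond that spread. They also leave open how much each structural difference between the two cores contributes on its own.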